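The compounds below may be only part of what the source reports. "The series", "measured", "known", "first", "only" and "open" are said of these compounds alone.

Compound 1, `CC[C@@H](Nc1c(C#N)c(-c2ccc(-c3cccc(OC)c3)cc2)nc2cnccc12)C(N)=O`, with 2.7 in a physicochemical assay for lipophilicity, read by HPLC, at pH 7.5; on this read-out lower numbers stand for lower lipophilicity and higher numbers for higher lipophilicity.
Compound 2, `CC[C@@H](Nc1c(C#N)c(-c2ccc(-c3cccc(C)c3F)cc2)nc2cnccc12)C(N)=O`, with 3 in this assay.
Compound 3, `CC[C@@H](Nc1c(C#N)c(-c2ccc(-c3cccc(C)c3)cc2)nc2cnccc12)C(N)=O`, with 3 in this assay.

Compound 3 stands level with compound 2 at the digits printed, the two of them together the highest of the three numbers, and its nearest neighbour is compound 2, with no change at the digits printed from compound 2 to compound 3 (within the scatter). The furthest is compound 1, with a number 0.30 log units higher from compound 1 to compound 3 (within the scatter), a step that also lies within the scatter. Compound 4, `CC[C@@H](Nc1c(C#N)c(-c2ccc(-c3cccc(Cl)c3)cc2)nc2cnccc12)C(N)=O`, has not yet been measured in this assay. It differs from compound 3 in one place: chloro in place of methyl on an aromatic carbon. Among the compounds with values here, none of the measured steps swaps methyl for chloro; the steps that touch the same ring, methoxy to methyl and fluoro to hydrogen, both stayed within the scatter. A move of the same small kind is therefore expected here, with a number 0.10 log units higher from compound 3 to compound 4 (within the scatter) reckoned as not beyond the scatter, leaning slightly upward. Compound 4 is thus estimated at 3.1, within a range of 2.8 to 3.4.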

Compound 4, distribution coefficient: 3.1
Compound 4: the middle estimate sits on the measured number at the digits printed; measured number inside the range.
By their numbers in this assay, from the lowest: compounds 1, 2, 3 and 4 (each within the scatter of the next, the first and the last beyond it).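

On this aromatic carbon, meta to a large group, chloro and methyl read alike in this assay (a number 0.10 log units higher from compound 3 to compound 4 (within the scatter)), and 3-chlorophenyl and 2-fluoro-3-methylphenyl also read alike (a number 0.10 log units higher from compound 2 to compound 4 (within the scatter)). New here is the first step at this position to lie beyond the scatter, though only a modest one (a number 0.40 log units higher from compound 1 to compound 4 (beyond the scatter)), whereas methyl in place of methoxy stayed within it. Nothing measured on these compounds bears on why chloro and methoxy differ in this way.

The compounds shown carry only methoxy, methyl and chloro at this position, so how an amine, a carboxylic acid or a longer chain would read there stays open. Also open, from the compounds shown here alone, is whether these steps would hold with other changes on the shared core.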